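Aryl amide variation on a shared core

The compounds below may be only part of what the source reports. "The series", "measured", "known", "first", "only" and "open" are said of these compounds alone.

The two measured compounds share one core and differ only in the aryl group on the amide carbonyl. Compound 1 `CCOC(=O)c1sc(-c2cccc(NC(=O)c3ccccc3)c2)nc1Nc1ccc(N2CCN(C)CC2)cc1` carries a phenyl there; in a functional assay on Ramos cells (Homo sapiens) for antiproliferative activity, read by CCK-8 assay, with a stated time of 72 h, tested at 40 uM (on this read-out higher numbers stand for more inhibition at the one concentration tested (going by the name of the read-out) and lower numbers for less inhibition), compound 1 gives 77.1%. Compound 2 `CCOC(=O)c1sc(-c2cccc(NC(=O)c3ccc(F)c(Cl)c3)c2)nc1Nc1ccc(N2CCN(C)CC2)cc1` carries 3-chloro-4-fluorophenyl at the same carbonyl; in this assay compound 2 gives 72.5%. Going by the values given here, the one measured step reads a number 4.6 percentage points lower from compound 1 to compound 2 (within the scatter). Compound 2 thus has the lower of the two numbers, with compound 1 nearest, but as that gap lies within the scatter no order between them can be asserted.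

Compound 3 `CCOC(=O)c1sc(-c2cccc(NC(=O)c3ccc(C(F)(F)F)cn3)c2)nc1Nc1ccc(N2CCN(C)CC2)cc1` is not yet measured. Its change from compound 2 is 5-(trifluoromethyl)pyridin-2-yl in place of 3-chloro-4-fluorophenyl on a carbonyl carbon. Among the compounds with values here, the only step that bears on this position is the one from compound 1 to compound 2, and it stayed within the scatter. Within the data shown here, the entering group brings a ring with one hetero atom and one hydrogen-bond acceptor, which no measured step covers, so the range is kept wide. No step beyond the scatter is expected in this assay, the expected step being a number 2.5 percentage points lower from compound 2 to compound 3 (within the scatter). Compound 3 is therefore expected to give about 70%, estimated between 52% and 84%.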

Compound 3, a percentage reported as inhibition, at one concentration (the size of the read-out at that concentration, not a potency): 19%
Estimate against measurement, compound 3: 51 percentage points above; the whole stated range lies above it.
By their numbers in this assay, from the lowest: compound 3; then compounds 2 and 1 (each within the scatter of the next).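

In this assay, 5-(trifluoromethyl)pyridin-2-yl in place of 3-chloro-4-fluorophenyl on the carbonyl carbon reads a number 53.5 percentage points lower from compound 2 to compound 3 (beyond the scatter), and the same group in place of phenyl reads a number 58.1 percentage points lower from compound 1 to compound 3 (beyond the scatter). The position therefore responds strongly to the group it carries, which the pair compound 1 and compound 2 could not show, since their values lie within the scatter of each other and both of their groups have a six-membered aromatic ring of carbon only. No measurement at hand bears on why the number falls at this change.

The entering group brings the ring hetero atom and the trifluoromethyl together, so the compounds shown cannot assign the step to either one alone. Unsubstituted pyridin-2-yl and 4-(trifluoromethyl)phenyl on the same carbonyl carbon would separate the two, and whether the step holds beyond this one read-out at a single concentration remains open.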